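A few compounds are considered here, and "the series" means these few. Any claim that something is new, unique, unknown or untested is made for them only; others in the source may bear on it.

Compound 1 `Fc1ccc2nc(-c3ccccc3)nc(Nc3ccccc3)c2c1`: in a functional assay on U2OS cells (Homo sapiens) for cytotoxicity, read by MTT assay, with a stated time of 48 h (on this read-out higher numbers stand for weaker inhibition and lower numbers for stronger inhibition), compound 1 gives > 50000 nM, which is a limit of the assay rather than a number.
Compound 2 `COc1ccccc1Nc1nc(-c2cccc(F)c2)nc2ccc(F)cc12`: in this assay compound 2 gives > 50000 nM, again a limit.
Compound 3 `Fc1ccc(Nc2nc(-c3cccc(F)c3)nc3ccc(F)cc23)cc1`: in this assay compound 3 gives > 50000 nM, also a limit.

Compound 3 therefore stands at the limit, and every measured value in this series sits at the same place, as the limit of > 50000 nM in this assay, at which 3 of the 3 values shown sit, records. Among the measured compounds shown here, the one step between measured compounds that changes a single group, a step that the two limits leave unreadable from compound 2 to compound 3, has no readable size, since both of its ends are limits.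

The unmeasured compound 4 `Fc1cccc(-c2nc(Nc3ccccc3F)c3cc(F)ccc3n2)c1` differs from compound 3 by 2-fluorophenyl in place of 4-fluorophenyl on a nitrogen on an aromatic ring. For the measured compounds named here, the only measured step that touches the group on that nitrogen is the step from compound 2 to compound 3, and it offers no size to build on. Going by the values given here, nothing among the measured compounds points to a step beyond the scatter in either direction, and the plain expectation is that compound 4 remains at the limit too.

Compound 4 is thus expected to give about 80000 nM in this assay, with a range from 20000 nM to 300000 nM. The expected step that the limit leaves unreadable from compound 3 to compound 4 would most likely stay hidden behind the limit.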

Compound 4, half-maximal inhibitory concentration: > 50000 nM
Compound 4 gave a limit, no number (the forecaster's own chance of this, stated with the estimate: 85%); the middle value lies beyond the limit too.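

Compound 4 gives > 50000 nM in this assay, which is a limit and not a number. The steps to compound 4 from compound 2 and compound 3 therefore cannot be read, and all the compounds share one position: the limit of > 50000 nM in this assay, at which 4 of the 4 values shown sit.

The compounds shown leave open which change to the shared core, if any, would bring a measurable value in these cells.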